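The source may report more compounds than this note shows. Statements on the series, on what has been measured and on what is new or still open speak of the compounds shown alone.

In a functional assay on A2780 cells (Homo sapiens) for antiproliferative activity, read by MTT assay, with a stated time of 48 h (on this read-out higher numbers stand for weaker inhibition and lower numbers for stronger inhibition), the measured compounds stand as follows:

Compound 1, `COc1ccc(C(=O)c2ccc(OC)c3c2C=CC(C)(C)O3)c(NC(=O)CO)c1`: 420 nM
Compound 2, `COc1ccc(C(=O)c2ccc(OC)c3c2C=CC(C)(C)O3)c(NC(=O)CN)c1`: 890 nM
Compound 3, `C=C(c1ccc(OC)cc1NC(=O)CO)c1ccc(OC)c2c1OC(C)(C)C=C2`: 40 nM

Compound 1 and compound 2 share one core and differ only by amino in place of hydroxy on a saturated chain carbon bound to a carbonyl carbon; this change produced a 2.1-fold higher number from compound 1 to compound 2 (0.33 log units; beyond the scatter). Compound 3 is built on a different core, and how its core differs from the core of compound 1 is not broken down here; of the three, compound 3 gives the lowest number in this assay.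

Compound 4, `C=C(c1ccc(OC)cc1NC(=O)CN)c1ccc(OC)c2c1OC(C)(C)C=C2`, carries the same change relative to compound 3: amino in place of hydroxy on a saturated chain carbon bound to a carbonyl carbon. Because this change occurs only once among the measured pairs, with a 2.1-fold higher number from compound 1 to compound 2 (0.33 log units; beyond the scatter), the step from compound 3 to compound 4 is expected to be similar, about a 2.1-fold higher number from compound 3 to compound 4 (0.33 log units; beyond the scatter). Compound 4 is therefore estimated to give 85 nM in this assay, with an expected range from 40 nM to 180 nM.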

Compound 4, half-maximal inhibitory concentration: 80 nM
Compound 4: middle estimate off by 1.1-fold (0.03 log units), on the high side; the measured number falls inside the stated range.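

On the core of compound 3, amino in place of hydroxy on a saturated chain carbon bound to a carbonyl carbon reads in this assay as a 2.0-fold higher number from compound 3 to compound 4 (0.30 log units; within the scatter), and the two steps on the two cores agree: the same change on two cores in this assay, a 2.1-fold higher number (0.33 log units; beyond the scatter) from compound 1 to compound 2 and a 2.0-fold higher number (0.30 log units; within the scatter) from compound 3 to compound 4, 1.1-fold (0.03 log units) apart, within the scatter of two such steps. In this series, then, the step carried from the core of compound 1 to the core of compound 3 without a difference that the scatter can separate. For the compounds shown here, this rests on only two pairs in one assay, so it neither establishes the same step on any further core nor explains why the step has this size.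

The compounds shown leave open how a methylamino group, a dimethylamino group or a longer chain carrying the amine would read at this place on either core. From the compounds shown here alone, a carboxylic acid there also remains open.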